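Benzoate substituent series: nitro replacing trifluoromethyl

This account rests on a few compounds, and the source may have more. Where it says the series, first, only, none or still open, it means among the compounds named here.

Among the measured compounds shown here, compound 1 `C=C1C(=O)[C@@]23C(=O)OC[C@]4([C@@H](OC(C)=O)CCC(C)(C)[C@H]4C=O)[C@@H]2CC[C@H]1[C@H]3OC(=O)c1ccc(C(F)(F)F)cc1` stands at the weaker end of the two measured members in a functional assay on MGC-803 cells (Homo sapiens) for inhibition, read by MTT assay (on this read-out lower numbers stand for stronger inhibition and higher numbers for weaker inhibition), giving 5540 nM, the highest of the two numbers in hand. For the measured compounds named here, compound 2 `C=C1C(=O)[C@@]23C(=O)OC[C@]4([C@@H](OC(C)=O)CCC(C)(C)[C@H]4C=O)[C@@H]2CC[C@H]1[C@H]3OC(=O)c1ccc(C)cc1` gives 1900 nM in this assay, so that a 2.9-fold lower number from compound 1 to compound 2 (0.46 log units; beyond the scatter) separates the pair; the single change there is methyl in place of trifluoromethyl on an aromatic carbon. Compound 3 `C=C1C(=O)[C@@]23C(=O)OC[C@]4([C@@H](OC(C)=O)CCC(C)(C)[C@H]4C=O)[C@@H]2CC[C@H]1[C@H]3OC(=O)c1ccc([N+](=O)[O-])cc1` is not yet measured. It differs from compound 1 by nitro in place of trifluoromethyl on an aromatic carbon. Going by the values given here, the only measured step touches the same aromatic carbon, but it exchanges trifluoromethyl for methyl rather than for nitro, so it says only that this position tolerates a change and that the step which followed was modest. Among the compounds with values here, no measured pair speaks to nitro at all. A step of similar size in either direction, or none beyond the scatter, is therefore the reasonable expectation for compound 3 in this assay, and the estimate sits close to compound 1 with a wide range. Compound 3 is estimated at 4000 nM, between 1500 nM and 12000 nM, which means an expected step of a 1.4-fold lower number from compound 1 to compound 3 (0.14 log units; within the scatter).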

Compound 3, half-maximal inhibitory concentration: 1980 nM
For compound 3 the middle estimate is 2.0-fold (0.31 log units) above the measured one; the measured number falls inside the stated range.
By their numbers in this assay, from the lowest: compounds 2 and 3 (each within the scatter of the next); then compound 1.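

In this assay, nitro in place of trifluoromethyl on the aromatic carbon gives a 2.8-fold lower number from compound 1 to compound 3 (0.45 log units; beyond the scatter) and so runs in the same direction as a 2.9-fold lower number from compound 1 to compound 2 (0.46 log units; beyond the scatter), which means that two different replacements of trifluoromethyl at this place now lower the number beyond the scatter. The third comparison, a 1.0-fold higher number from compound 2 to compound 3 (0.02 log units; within the scatter), lies within the scatter, so methyl and nitro cannot be told apart at this place in this read-out, even though the two groups share little in what is counted for them. Among the three benzoates, compound 1 is therefore the one that stands apart, with both of its steps beyond the scatter, and the series reads as trifluoromethyl against the other two groups rather than as a graded order; no measured property of these groups is at hand to bear on this result.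

On these data alone, whether an amine, a methoxy group, a chlorine atom or a carboxylic acid on the same aromatic carbon would fall with methyl and nitro or with trifluoromethyl remains open. Also open, as far as these compounds go, is whether the separation of compound 1 from the other two would hold with the same groups on another carbon of the ring, or with the acetate on the shared core exchanged for a longer chain.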